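The source may hold more compounds than are shown below. What is called first, only, known or untested is meant among the compounds shown, and "the series" means these compounds.

Measured compounds in an ADME assay on HFF cells (Homo sapiens) for cytotoxicity, with a stated time of 8 days; on this read-out higher numbers stand for lower toxicity in this test and lower numbers for higher toxicity in this test:
Compound 1 `CC(C)CSc1nc(N)nc2c1ncn2/C=C1/CC1(CO)CO` gives > 300000 nM in this assay, which is a limit of the assay and not a number.
Compound 2 `Nc1nc(NC2CCCC2)c2ncn(/C=C3/CC3(CO)CO)c2n1` gives > 300000 nM in this assay, again a limit.
Compound 3 `CSc1nc(N)nc2c1ncn2/C=C1/CC1(CO)CO` gives > 300000 nM in this assay, also a limit.

Compound 3 thus stands at the limit, as shown by the limit of > 300000 nM in this assay, at which 3 of the 3 values shown sit. Compound 4 `Nc1nc(SCc2ccccc2)c2ncn(/C=C3/CC3(CO)CO)c2n1` has not yet been measured; it differs from compound 3 by phenyl in place of hydrogen on a saturated chain carbon bound to a sulfur. The steps that touch the same place are a step that the two limits leave unreadable from compound 1 to compound 3 and a step that the two limits leave unreadable from compound 2 to compound 3, and the remaining step that the two limits leave unreadable from compound 1 to compound 2; none of them can be read, so no size or direction in this assay can be expected from them. For compound 4 the step of a number no higher from compound 3 to compound 4 (the limit leaves the size open) is therefore estimated as lying within the scatter. The estimated value for compound 4 is 300000 nM, with a range of 100000 nM to 900000 nM.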

Compound 4, half-maximal cytotoxic concentration: > 300000 nM
Compound 4 was reported as a limit; the forecaster's own chance of this, stated with the estimate: 70%; the middle value sits exactly at the limit.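

No step among compound 1, compound 2, compound 3 and compound 4 can be read in this assay, because each value is a limit of the assay and not a number: the limit of > 300000 nM in this assay, at which 4 of the 4 values shown sit.

The compounds shown leave open at what concentration any of them would become toxic to these cells, and whether the changed groups alter that concentration.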